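Chain shortening on the core of compound 2

The source may hold more compounds than are shown below. What is called first, only, known or untested is meant among the compounds shown, and "the series" means these compounds.

Measured so far:
compound 1 `CCCCc1nc2cccnc2n1Cc1cc(Cl)c(O)c(Cl)c1`: 63.1 nM
compound 2 `CCCCc1nc2ncccc2n1Cc1cc(Cl)c(O)c(Cl)c1`: 398 nM

In a functional assay (aorta) with Oryctolagus cuniculus as the target (on this read-out higher numbers stand for weaker binding and lower numbers for tighter binding), compound 1 gives 63.1 nM and compound 2 gives 398 nM; of these two numbers compound 2 holds the higher one, and its gap to compound 1 lies beyond the scatter. Compound 3 `CCCc1nc2ncccc2n1Cc1cc(Cl)c(O)c(Cl)c1` is not yet measured. It differs from compound 2 only in hydrogen in place of methyl on a saturated chain carbon, three bonds along the chain from an aromatic carbon. Among the compounds with values here, no step between measured compounds bears on this change, so its direction is uncertain; a step from compound 2 to compound 3 of a 2.0-fold higher number from compound 2 to compound 3 (0.30 log units; within the scatter) toward a higher number is expected, though one within the scatter would not surprise. The estimate for compound 3 is 800 nM, with a range of 250 nM to 2500 nM.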

Compound 3, dissociation constant: 794 nM
Compound 3: the middle estimate sits 1.0-fold (0.00 log units) above what was measured; the measured number falls inside the stated range.
By their numbers in this assay, from the lowest: compound 1; then compounds 2 and 3 (each within the scatter of the next).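

In this assay, the change from butyl to propyl on this core gives a 2.0-fold higher number from compound 2 to compound 3 (0.30 log units; within the scatter), the first step read at this position. Shortening the chain by this one carbon therefore cannot be told apart from repeat scatter, and neither chain length can be ranked above the other on this core. Nothing available bears on a reason for this result.

Still open, going by these compounds, is whether a pentyl chain, or a chain ending in an amine, would stand clear of butyl and propyl on this core. Also open, on these data alone, is whether propyl on the core of compound 1 would read the same way.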